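The compounds below may be only part of what the source reports. "The series", "measured", "known", "first", "only" and "open" are said of these compounds alone.

Series measured in a functional assay on MCF7 cells (Homo sapiens) for cytotoxicity; a lower number here means a stronger inhibitor, a higher number a weaker inhibitor:
- compound 1 `Cc1ccc2nc(NC(=O)CCCCCCC(=O)NO)sc2c1`: 1.6 ug/mL
- compound 2 `O=C(CCCCCCC(=O)Nc1nc2ccc([N+](=O)[O-])cc2s1)NO`: 3.83 ug/mL
- compound 3 `CCOc1ccc2nc(NC(=O)CCCCC(=O)NO)sc2c1`: 8.72 ug/mL

Compound 3 has the highest number of the three in this assay. The next structure, compound 4 `CCOc1ccc2nc(NC(=O)CCCCCCC(=O)NO)sc2c1`, differs from it by 2-(hydroxycarbamoyl)ethyl in place of hydroxycarbamoyl on a saturated chain carbon, four bonds along the chain from a carbonyl carbon. Among the compounds with values here, no measured step covers this change. The only one, a 2.4-fold higher number from compound 1 to compound 2 (0.38 log units; beyond the scatter), is modest and lies elsewhere, as nitro in place of methyl on an aromatic carbon. Still, compound 1 at 1.6 ug/mL and compound 2 at 3.83 ug/mL share the chain of compound 4, so a lower number is expected, with the estimated step being a 3.1-fold lower number from compound 3 to compound 4 (0.49 log units; beyond the scatter). Compound 4 is expected at 2.8 ug/mL, within 1.1 ug/mL to 7 ug/mL.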

Compound 4, half-maximal inhibitory concentration: 11.6 ug/mL
Beside the measured number, compound 4's estimate is 4.1-fold (0.62 log units) below it, and the stated range ends below it.
By their numbers in this assay, from the lowest: compound 1; then compound 2; then compounds 3 and 4 (each within the scatter of the next).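

In this assay the step of a 1.3-fold higher number from compound 3 to compound 4 (0.12 log units; within the scatter) shows that, with ethoxy on the aromatic carbon, 2-(hydroxycarbamoyl)ethyl in place of hydroxycarbamoyl does not separate the two compounds. With the chain held, the aromatic group does separate them: the step of a 3.0-fold higher number from compound 2 to compound 4 (0.48 log units; beyond the scatter) replaces nitro with ethoxy and the step of a 7.3-fold higher number from compound 1 to compound 4 (0.86 log units; beyond the scatter) replaces methyl with ethoxy. No evidence at hand accounts for either result. Open, from the compounds shown here alone, is whether the chain change reads the same with methyl or nitro on the core. Also open, going by these compounds, is how an amine on that aromatic carbon, or a longer chain, would compare.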